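This account rests on a few compounds, and the source may have more. Where it says the series, first, only, none or still open, it means among the compounds named here.

Values in an ADME assay on HEK293 cells (Homo sapiens) for cytotoxicity, read by resazurin assay, with a stated time of 48 h; a lower number here means that less compound is tolerated, a higher number that more compound is tolerated:
compound 1 `O=S(=O)(Nc1ccc(-c2nc3ccccc3o2)cc1)c1ccccc1C(F)(F)F`: > 100000 nM, a limit of the assay
compound 2 `CCc1ccc(S(=O)(=O)Nc2ccc(-c3nc4ccccc4o3)cc2)cc1`: 82000 nM
compound 3 `C=Cc1ccc(S(=O)(=O)Nc2ccc(-c3nc4ccccc4o3)cc2)cc1`: > 100000 nM, a limit of the assay

Compound 3 stands at the upper edge of what this assay reports, (the limit of > 100000 nM in this assay, at which 2 of the 3 values shown sit); its value is a limit, not a number. Compound 4 `COc1ccccc1S(=O)(=O)Nc1ccc(-c2nc3ccccc3o2)cc1` differs from compound 3 by 2-methoxyphenyl in place of 4-vinylphenyl on a sulfonyl sulfur. Among the compounds with values here, the one measured step, an at least 1.2-fold higher number from compound 2 to compound 3 (0.08 log units; that floor lies within the scatter), is a small change on an aromatic carbon and lies within the scatter; no measured step involves a 2-methoxyphenyl, so it bears only loosely on this change. Compound 4 is therefore expected to remain at the limit, with no step beyond the scatter, estimated as a number no higher from compound 3 to compound 4 (the limit leaves the size open). The estimate for compound 4 is 100000 nM, with a range from 50000 nM to 200000 nM.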

Compound 4, half-maximal cytotoxic concentration: > 100000 nM
Compound 4 was reported as a limit (the forecaster's own chance of this, stated with the estimate: 70%); the middle value sits exactly at the limit.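

In this assay compound 4, with 2-methoxyphenyl on the sulfonyl sulfur, gives > 100000 nM, a limit of the assay, so methoxy on this aryl group also leaves the series at the edge of the read-out: the limit of > 100000 nM in this assay, at which 3 of the 4 values shown sit.

Within the data shown here, the one readable comparison is an at least 1.2-fold higher number from compound 2 to compound 4 (0.08 log units; that floor lies within the scatter), and the steps that join two limits cannot be read.

On these data alone, whether an amine or a carboxylic acid in place of methoxy would give a true number in this assay remains open. As far as these compounds go, how far the compounds at the limit differ from one another also remains open.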